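The source may report more compounds than this note shows. Statements on the series, on what has been measured and on what is new or still open speak of the compounds shown alone.

Measured compounds in a functional assay on CHO-K1 cells for antagonist activity at transient receptor potential cation channel subfamily V member 1 (Homo sapiens), read by FLIPR; a higher number here means a weaker inhibitor, a lower number a stronger inhibitor:
- compound 1 `CC(C(=O)NCc1ccc(C(F)(F)F)nc1N(C)C)c1ccc(NS(C)(=O)=O)c(F)c1`: 19.1 nM
- compound 2 `CC(C(=O)NCc1ccc(C(F)(F)F)nc1N1CCCCC1C)c1ccc(NS(C)(=O)=O)c(F)c1`: 2.9 nM
- compound 3 `CC(C(=O)NCc1ccc(C(F)(F)F)nc1N1CCC(O)CC1)c1ccc(NS(C)(=O)=O)c(F)c1`: "not active" (no number reported), no number
- compound 4 `CC(C(=O)NCc1ccc(C(F)(F)F)nc1N1CCN(C)CC1)c1ccc(NS(C)(=O)=O)c(F)c1`: not yet measured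

Compound 3 stands without a number in this assay; it is reported only as not active, so it sits at the weak end of the series, below any value that can be placed on the scale. The change from compound 3 to compound 4 is 4-methylpiperazin-1-yl in place of 4-hydroxypiperidin-1-yl on an aromatic carbon.

For the measured compounds named here, the one measured step at this position is a 6.6-fold lower number from compound 1 to compound 2 (0.82 log units; beyond the scatter), which exchanges one amine substituent for another on the same aromatic carbon. It shows that the group at this carbon can move the number by a modest amount. Going by the values given here, no step links compound 3 or compound 4 to the others by a single change, and the two ring substituents at issue here are of similar size, each carrying two hydrogen-bond acceptors, with the hydrogen-bond donor of compound 3 removed in compound 4. With compound 3 inactive and no direct comparison available, the expectation for compound 4 is a weak inhibitor, likely weaker than compound 1, with a wide range and a real chance that only a limit is reported. The estimate for compound 4 in this assay is 800 nM, expected between 60 nM and 10000 nM.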

Compound 4, inhibition constant: 146 nM
The estimate for compound 4 lay 5.5-fold (0.74 log units) above the measured number, and the stated range covers the measured number.
By their numbers in this assay, from the lowest: compound 2; then compound 1; then compound 4.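

In this assay, for the compounds shown here, compound 4 gives 146 nM with its 4-methylpiperazin-1-yl group, whereas compound 3, with 4-hydroxypiperidin-1-yl, is reported only as not active, so no step from compound 3 can be read. The range at this aromatic carbon is wider than the earlier pair showed, with a 50-fold higher number from compound 2 to compound 4 (1.70 log units; beyond the scatter) and a 7.6-fold higher number from compound 1 to compound 4 (0.88 log units; beyond the scatter) as well. A six-membered ring here therefore does not by itself give a lower number than dimethylamino: compound 2 lies below compound 1, and compound 4 lies above it.

On these data alone, whether an unsubstituted piperidine or a morpholine at this carbon would fall nearer compound 2 or compound 4 remains open. Nothing measured here gives a reason for the size of these steps.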